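Carbamate-Bearing Chain in Place of Cyclohexylmethyl on Compound 1

A few compounds are considered here, and "the series" means these few. Any claim that something is new, unique, unknown or untested is made for them only; others in the source may bear on it.

Compound 1 `CCCSc1nc(Cl)c2c(n1)N(CC1CCCCC1)C(C(=O)N1CCN(C)CC1)N2` gives only a limit in a functional assay on TE-1 cells (Homo sapiens) for antiproliferative activity, read by MTT assay, with a stated time of 72 h; on this read-out lower numbers stand for stronger inhibition and higher numbers for weaker inhibition: compound 1 reads > 64000 nM, which is a limit of the assay and not a number. Compound 3 `CCCSc1nc(Cl)c2c(n1)N(Cc1ccccc1)C(C(=O)NCCNC(=O)OC(C)(C)C)N2` likewise reaches only a limit in this assay, reading > 64000 nM. Among the compounds with values here, compound 2 `CCCSc1nc(Cl)c2c(n1)N(Cc1ccccc1)C(C(=O)NCCC1=CCc3ccccc31)N2` is the one member of the set with a numeric value, giving 30000 nM in this assay. Within the data shown here, the single measured step that speaks to the change, an at least 2.1-fold higher number from compound 2 to compound 3 (0.32 log units; beyond the scatter), exchanged an indene-bearing chain for a tert-butoxycarbonylamino-bearing chain on the amide side and pushed the reading up to the limit of > 64000 nM in this assay, at which 2 of the 3 values shown sit. Compound 4 `CCCSc1nc(Cl)c2c(n1)N(CCNC(=O)OC(C)(C)C)C(C(=O)N1CCN(C)CC1)N2` arises from compound 1 by ((tert-butoxycarbonyl)amino)methyl in place of cyclohexyl on a saturated chain carbon bound to a nitrogen on an aromatic ring in a ring, so the same kind of carbamate chain now sits on the ring nitrogen rather than on the amide. With compound 1 already at a limit, no resolvable step is expected in this assay, and a further limit is the most likely outcome. Compound 4 is therefore expected to give 100000 nM, spanning 40000 nM to 300000 nM. That estimate amounts to a step that the limit leaves unreadable from compound 1 to compound 4, nothing beyond the scatter.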

Compound 4, half-maximal inhibitory concentration: 51800 nM
Beside the measured number, compound 4's estimate is 1.9-fold (0.29 log units) above it; the range from low to high includes it.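

In this assay, ((tert-butoxycarbonyl)amino)methyl in place of cyclohexyl on a saturated chain carbon bound to a nitrogen on an aromatic ring in a ring gives an at least 1.2-fold lower number from compound 1 to compound 4 (0.09 log units; that floor lies within the scatter). This is the only step shown at this position, and with it compound 4 reads 51800 nM, a numeric value. Its full size cannot be fixed, because compound 1 reads only a limit and not a number: the limit of > 64000 nM in this assay, at which 2 of the 4 values shown sit.

From the compounds shown here alone, whether a free primary amine or a carboxylic acid at the end of this chain would give a step beyond the scatter remains open. So does the question of whether a longer chain or a plain benzyl group at this position, with the same amide on the core of compound 4, would read differently in this assay.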